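Aryl ester series: swapping the para group of compound 3

A few compounds are considered here, and "the series" means these few. Any claim that something is new, unique, unknown or untested is made for them only; others in the source may bear on it.

Three compounds of the shared core have numbers in a functional assay on PC-3 cells (Homo sapiens) for antiproliferative activity, read by sulforhodamine B assay, with a stated time of 48 h, tested at 50 uM; a lower number here means less inhibition, a higher number more inhibition at the concentration tested (going by the name of the read-out). Compound 1 `COc1cccc(C(=O)Oc2cc3c(cc2C)[C@@H](C(C)C)CC=C3C)c1` gives 16.3%. Compound 2 `CC1=CC[C@H](C(C)C)c2cc(C)c(OC(=O)Nc3ccccc3)cc21` gives 93.2%. Compound 3 `CC1=CC[C@H](C(C)C)c2cc(C)c(OC(=O)c3ccc([N+](=O)[O-])cc3)cc21` gives 36.7%, the second highest of the three, nearer to compound 1 than to compound 2. Compound 4 `CC1=CC[C@H](C(C)C)c2cc(C)c(OC(=O)c3ccc(C(F)(F)F)cc3)cc21` is not yet measured; it differs from compound 3 by trifluoromethyl in place of nitro on an aromatic carbon. For the measured compounds named here, only one measured step alters the aryl ring of the ester alone: a number 20.4 percentage points higher from compound 1 to compound 3 (beyond the scatter), a modest move. The step of a number 56.5 percentage points lower from compound 2 to compound 3 (beyond the scatter) exchanges an anilino for an aryl group and says little about changing one substituent on that ring. Given that a number 20.4 percentage points higher from compound 1 to compound 3 (beyond the scatter) was modest, the step of a number 4.7 percentage points lower from compound 3 to compound 4 (within the scatter) is expected to remain within the scatter. Compound 4 is estimated at 32%, with a range of 15% to 50%.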

Compound 4, a percentage reported as inhibition, at one concentration (the size of the read-out at that concentration, not a potency): 12.3%
Estimate against measurement, compound 4: 19.7 percentage points above, outside the stated range (below it).
By their numbers in this assay, from the lowest: compounds 4 and 1 (each within the scatter of the next); then compound 3; then compound 2.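

At the aromatic carbon para to a large group, trifluoromethyl in place of nitro gives a number 24.4 percentage points lower from compound 3 to compound 4 (beyond the scatter) in this assay. The earlier aryl step changed both the substituent and its place on the ring, whereas this one holds the place fixed, so the substituent exchange alone moves the read-out beyond the scatter. Nothing at hand bears on the reason for this step.

Going by these compounds, whether an amine or a carboxylic acid on this carbon would read nearer compound 3 or compound 4 remains open. Also open, on these data alone, is whether the same exchange would give a similar step on the anilino carbonyl series of compound 2.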